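The source may hold more compounds than are shown below. What is called first, only, known or untested is meant among the compounds shown, and "the series" means these compounds.

Measured compounds:
compound 1 `COc1ccc(C(O)c2c(-c3ccccc3)c(-c3ccccc3)n3ccc(C#N)cc23)cc1` — "not determined" (no result reported) in an assay for inhibition of Polyunsaturated fatty acid lipoxygenase ALOX15 (Oryctolagus cuniculus); a higher number here means a weaker inhibitor, a lower number a stronger inhibitor
compound 2 `N#Cc1ccn2c(-c3ccccc3)c(-c3ccccc3)c(CO)c2c1` — 34000 nM in this assay
compound 3 `N#Cc1ccn2c(-c3ccccc3)c(-c3ccccc3)c(OCOC(COCc3ccccc3)COCc3ccccc3)c2c1` — "not determined" (no result reported) in this assay

Going by the values given here, compound 2 carries the only number; compounds 1 and 3 have no result, so no comparison with them is possible. Compound 4 `N#Cc1ccn2c(-c3ccccc3)c(-c3ccccc3)c(C=O)c2c1` differs from compound 2 in one place: formyl in place of hydroxymethyl on an aromatic carbon. Among the compounds with values here, no measured step between two measured compounds exists to calibrate this change. Since compound 2 sits at a weak level with 34000 nM, the expectation is a small step, at most modestly toward a stronger inhibitor and possibly none beyond the scatter. Compound 4 is therefore estimated at 20000 nM, with a range of 6000 nM to 70000 nM. The estimated step from compound 2 to compound 4 is a 1.7-fold lower number from compound 2 to compound 4 (0.23 log units; within the scatter).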

Compound 4, half-maximal inhibitory concentration: 61000 nM
Compound 4: middle estimate off by 3.1-fold (0.48 log units), on the low side, and the stated range covers the measured number.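

Formyl in place of hydroxymethyl on this aromatic carbon gives a 1.8-fold higher number from compound 2 to compound 4 (0.25 log units; within the scatter) in this assay. The hydrogen-bond donor of hydroxymethyl can thus be lost here without a change beyond the scatter, and both compounds stay at a weak level. No measurement bearing on the reason accompanies this result.

As far as these compounds go, whether an amine, a carboxylic acid or a longer chain on this carbon would move the number beyond the scatter remains open. Compound 1 and compound 3 have no result, so their groups at this carbon cannot be read.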